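Thienopyrimidine series: carbonyl substituent change toward compound 3

The source may hold more compounds than are shown below. What is called first, only, known or untested is meant among the compounds shown, and "the series" means these compounds.

Compound 1 `O=C(c1ccccc1)c1nc(NCc2cccnc2)nc2ccsc12` is measured in a functional assay on CHO-K1 cells for antagonist activity at adenosine receptor A2b (Homo sapiens), read by FLIPR and calcium flux (on this read-out lower numbers stand for stronger inhibition and higher numbers for weaker inhibition), where compound 1 gives 511 nM. Compound 2 `O=C(c1cccnc1)c1nc(NCc2cccnc2)nc2ccsc12` carries pyridin-3-yl in place of phenyl on the carbonyl carbon, and in this assay compound 2 gives 109 nM. Going by the values given here, the one step in hand, a 4.7-fold lower number from compound 1 to compound 2 (0.67 log units; beyond the scatter), is beyond the scatter. Among the compounds with values here, on these two numbers compound 2 stands lowest, with compound 1 as its only neighbour.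

Compound 3 `O=C(NC1CC1)c1nc(NCc2cccnc2)nc2ccsc12` differs from compound 2 as follows: cyclopropylamino in place of pyridin-3-yl on a carbonyl carbon. Cut one bond further out, the change reads (pyridin-3-yl)carbonyl to cyclopropylcarbamoyl. Within the data shown here, only the step from compound 1 to compound 2 touches the same carbonyl position, and it shows that this position moves the number in this assay by a modest amount. Among the measured compounds shown here, no measured pair covers a cyclopropylamino at this place, so the direction is open; the estimate stays near compound 2 with a wide range, leaning toward a somewhat higher number, expected as a 2.8-fold higher number from compound 2 to compound 3 (0.44 log units; beyond the scatter). For compound 3 the expected value in this assay is 300 nM, within the range 60 nM to 1500 nM.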

Compound 3, half-maximal inhibitory concentration: 256 nM
Estimate against measurement, compound 3: 1.2-fold (0.07 log units) above; low and high end bracket the measured number.
By their numbers in this assay, from the lowest: compound 2; then compounds 3 and 1 (each within the scatter of the next).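

Swapping the aromatic ring on the carbonyl carbon for cyclopropylamino does not keep all of the number reached with pyridin-3-yl in this assay: the step is a 2.3-fold higher number from compound 2 to compound 3 (0.37 log units; beyond the scatter), and compound 2 stays lowest of the three, with its steps to the other two both printed as beyond the scatter. Against the phenyl group the picture differs, since a 2.0-fold lower number from compound 1 to compound 3 (0.30 log units; within the scatter) places compound 1 and compound 3 on a level that this read-out cannot separate, so at this place a non-aromatic three-membered ring joined through an amide nitrogen sits level with phenyl, and of the three groups only pyridin-3-yl stands apart. Nothing at hand accounts for the gap between pyridin-3-yl and cyclopropylamino.

Three groups at a single place cannot show whether the amide hydrogen of compound 3 or its cyclopropyl ring sets its number, and a dimethylamino group or a cyclopropyl ring bonded directly to the carbonyl carbon would pull those two apart. Also open, as far as these compounds go, is whether the pyridine nitrogen counts at another ring place, as a pyridin-2-yl or pyridin-4-yl group on the same carbonyl carbon would show.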